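The compounds below may be only part of what the source reports. "The series", "measured", "known", "first", "only" and "open" are said of these compounds alone.

Measured compounds:
- compound 1 `[O-][S+](Cc1cccs1)C(c1ccc(Cl)cc1)c1ccc(Cl)cc1`, in an assay on HEK293 cells for inhibition of sodium-dependent dopamine transporter (Homo sapiens), read by scintillation counting, with stated times of 5 min and 1 min (on this read-out higher numbers stand for weaker inhibition and lower numbers for stronger inhibition), compound 1 gives 7200 nM
- compound 2 `[O-][S+](Cc1cccs1)C(c1ccc(F)cc1)c1ccc(F)cc1`, in this assay compound 2 gives 4000 nM
- compound 3 `[O-][S+](Cc1cc(Br)cs1)C(c1ccccc1)c1ccccc1`, in this assay compound 3 gives 13700 nM

Compound 3 carries the highest number of the three. Against compound 1 the gap is within the scatter of repeated measurements, so nothing can be said about their order. Against compound 2 the gap lies beyond the scatter, so compound 2 gives the lower number of that pair.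

Compound 4 `[O-][S+](Cc1ccsc1Br)C(c1ccccc1)c1ccccc1` is the next compound in the series and has not yet been measured in this assay. It differs from compound 3 only in the heteroaryl group on the methylene: 2-bromothiophen-3-yl in place of 4-bromothiophen-2-yl on a saturated chain carbon bound to a sulfur. The two compounds have the same atoms, joined differently, so the change is a move of the bromine within the thiophene ring and of the thiophene's point of attachment.

Among the measured compounds shown here, no step between measured compounds of this kind exists, so there is nothing to calibrate against. The expectation is a step of a 1.1-fold lower number from compound 3 to compound 4 (0.06 log units; within the scatter) that stays within the scatter, in no particular direction. Compound 4 is therefore expected to give about 12000 nM in this assay, with a range from 5000 nM to 30000 nM.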

Compound 4, half-maximal inhibitory concentration: 29300 nM
Estimate against measurement, compound 4: 2.4-fold (0.39 log units) below, within the range that was stated.
By their numbers in this assay, from the lowest: compounds 2, 1 and 3 (each within the scatter of the next, the first and the last beyond it); then compound 4.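

In this assay the swap of 4-bromothiophen-2-yl for 2-bromothiophen-3-yl on a saturated chain carbon bound to a sulfur gives a 2.1-fold higher number from compound 3 to compound 4 (0.33 log units; beyond the scatter) with the same atoms and the same counts on both sides. Rearrangement alone, with nothing added or removed, is therefore enough to move the number beyond the scatter at this position, though the step is modest in size. Among the compounds shown here, this is the first step between compounds that differ in one place, and no measurement at hand offers an explanation for it.

Going by these compounds, the bromine and the thiophene's point of attachment move together in this pair, so their separate contributions remain open. Also open, on these data alone, is how an amine or a carboxylic acid in place of the bromine would read at this position.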